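A few compounds are considered here, and "the series" means these few. Any claim that something is new, unique, unknown or untested is made for them only; others in the source may bear on it.

Measured compounds

Compound 1 `O=C(N/N=C/c1c(-c2cc3ccccc3oc2=O)[nH]c2ccccc12)c1ccccc1F`: > 200000 nM
Compound 2 `O=C(N/N=C/c1c(-c2cc3ccccc3oc2=O)[nH]c2ccccc12)c1ccc(Cl)cc1F`: > 200000 nM
Compound 3 `O=C(N/N=C/c1c(-c2cc3ccc(Br)cc3oc2=O)[nH]c2ccccc12)c1ccccc1`: > 200000 nM

All three values come from a toxicity assay on Vero cells (Chlorocebus sabaeus) for inhibition, read by MTT assay, with a stated time of 48 h (a higher number here means a weaker inhibitor, a lower number a stronger inhibitor), and each is a limit of the assay rather than a number. For compound 1 the result in this assay is a limit, > 200000 nM. For compound 2 it is likewise a limit, > 200000 nM. For compound 3 it is again a limit, > 200000 nM. The change from compound 1 to compound 2 is chloro in place of hydrogen on an aromatic carbon, and its step in this assay is a step that the two limits leave unreadable from compound 1 to compound 2; that it cannot be read is due to the limit of > 200000 nM in this assay, at which 3 of the 3 values shown sit.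

The difference between the core of compound 1 and the core of compound 3 is not broken down here.

Compound 4 `O=C(N/N=C/c1c(-c2cc3ccc(Br)cc3oc2=O)[nH]c2ccccc12)c1ccc(Cl)cc1` is not yet measured. It differs from compound 3 by chloro in place of hydrogen on an aromatic carbon. Going by the values given here, this is the same kind of change as the one from compound 1 to compound 2, but not the same: there the entering chloro sits meta to a fluoro group, while in compound 4 no fluoro group is present on that ring.

Since every compound shown sits at the same limit in this assay, compound 4 is expected to do the same; the expected step from compound 3 is a step that the limit leaves unreadable from compound 3 to compound 4. The estimate for compound 4 in this assay is 250000 nM, with an expected range from 100000 nM to 600000 nM, resting on the limits found for compound 1, compound 2 and compound 3 and on (the limit of > 200000 nM in this assay, at which 3 of the 3 values shown sit).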

Compound 4, half-maximal inhibitory concentration: 71400 nM
Compound 4: the middle estimate sits 3.5-fold (0.54 log units) above what was measured, and the stated range ends above it.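

In this assay, 4-chlorophenyl in place of phenyl on the core of compound 3 gives an at least 2.8-fold lower number from compound 3 to compound 4 (0.44 log units; beyond the scatter), so on this core the change does lower the number. The same kind of change on the core of compound 1, made on a ring that also carries a fluoro group, cannot be read, and nothing can yet be said about whether the change carries over from one core to the other, due to the assay limit that holds most of the series: the limit of > 200000 nM in this assay, at which 3 of the 4 values shown sit. Compound 2 gives only a limit, > 200000 nM, which shows neither a step of the size seen on the core of compound 3 nor the absence of one.

Whether the lower number is specific to chloro stays open, since the compounds shown do not reveal what an amine, a carboxylic acid or a methoxy group would do in the same place on the phenyl ring. Also open, on these data alone, is whether a fluoro group on that ring, as in compound 2, would alter the step on the core of compound 3.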